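Replacing the methyl on sulfur in a quinazoline-type series

A few compounds are considered here, and "the series" means these few. Any claim that something is new, unique, unknown or untested is made for them only; others in the source may bear on it.

The two measured compounds share one core. Compound 1 is `COc1ccc(CNc2nc([SeH])nc3ccccc23)cc1` and compound 2 is `COc1ccc(CNc2nc(SC)nc3ccccc23)cc1`. In a functional assay on MCF7 cells (Homo sapiens) for cytotoxicity, read by MTT assay, with a stated time of 72 h (on this read-out lower numbers stand for stronger inhibition of growth and higher numbers for weaker inhibition of growth), compound 1 gives 94000 nM, and in the same assay compound 2 gives 85100 nM. Within the data shown here, the single measured step, a 1.1-fold lower number from compound 1 to compound 2 (0.04 log units; within the scatter), falls within the scatter, so compound 2 stands lowest of the two numbers only nominally, with compound 1 next to it at a distance that carries no meaning.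

Compound 3 is `COc1ccc(CNc2nc(S)nc3ccccc23)cc1`. It differs from compound 2 by hydrogen in place of methyl on a sulfur. Among the measured compounds shown here, no measured step changes exactly this group, so the only bearing comes from the step from compound 1 to compound 2, where exchanging a bare selenium atom for a methyl-bearing sulfur left this assay unmoved. Compound 3 carries a bare sulfur, the nearest counterpart to the bare selenium of compound 1, and no movement beyond the scatter is therefore expected from a 1.1-fold higher number from compound 2 to compound 3 (0.02 log units; within the scatter). The value for compound 3 is estimated at 90000 nM, with a likely range from 40000 nM to 200000 nM.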

Compound 3, concentration for total growth inhibition: 36500 nM
For compound 3 the middle estimate is 2.5-fold (0.39 log units) above the measured one; the whole stated range lies above it.
By their numbers in this assay, from the lowest: compound 3; then compounds 2 and 1 (each within the scatter of the next).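

The sulfanyl compound shows that this place on the shared core is not indifferent in this assay, as the earlier pair alone might have suggested: hydrogen in place of methyl on the sulfur gives a 2.3-fold lower number from compound 2 to compound 3 (0.37 log units; beyond the scatter), and one sulfur atom in place of one selenium atom on the aromatic carbon gives a 2.6-fold lower number from compound 1 to compound 3 (0.41 log units; beyond the scatter). Both steps are modest, but both lie beyond the scatter, so compound 3 stands apart from compound 1 and compound 2, which remain within the scatter of each other. Nothing available here accounts for this difference.

The compounds shown leave open how an amine, a hydroxyl or a longer chain such as ethyl on the sulfur would stand in this assay, and so whether the methyl step reflects something particular to methyl. They also leave open what methyl on the selenium would do, and with only three compounds on one core in one cell line, the steps cannot be extended to any other series or read-out.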